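From compound 2 to compound 3: a methyl replaced

The source may hold more compounds than are shown below. What is called first, only, known or untested is meant among the compounds shown, and "the series" means these compounds.

Compound 1 `COc1cc(OC)c2sc(-c3ccc(N/C=C\C(=O)c4ccc(OC)c([N+](=O)[O-])c4)cc3)nc2c1`: 5800 nM
Compound 2 `COc1cc(OC)c2sc(-c3ccc(N/C=C\C(=O)c4cc(OC)c(OC)c(OC)c4)c(C)c3)nc2c1`: 14400 nM

In a functional assay on A549 cells (Homo sapiens) for antiproliferative activity, read by sulforhodamine B assay, with a stated time of 48 h (a lower number here means a stronger inhibitor, a higher number a weaker inhibitor), compound 2 has the higher of the two numbers at 14400 nM, and the gap to compound 1 at 5800 nM lies beyond the scatter. Compound 3 `COc1cc(OC)c2sc(-c3ccc(N/C=C\C(=O)c4cc(OC)c(OC)c(OC)c4)cc3)nc2c1` carries hydrogen in place of methyl on an aromatic carbon of compound 2 (hydrogen in place of methyl on an aromatic carbon). Within the data shown here, no measured pair shows this change alone. Compound 1, which lacks this methyl, gives 5800 nM, so a moderate fall in the number is expected, with a 2.4-fold lower number from compound 2 to compound 3 (0.38 log units; beyond the scatter) as the estimated step. Compound 3 is expected at 6000 nM, with an estimated range of 1500 nM to 20000 nM.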

Compound 3, half-maximal inhibitory concentration: 21800 nM
Beside the measured number, compound 3's estimate is 3.6-fold (0.56 log units) below it, outside the stated range (above it).
By their numbers in this assay, from the lowest: compound 1; then compounds 2 and 3 (each within the scatter of the next).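

In this assay, hydrogen in place of methyl on this aromatic carbon gives a 1.5-fold higher number from compound 2 to compound 3 (0.18 log units; within the scatter), so the methyl at this position has no effect that can be told from the scatter. The step that does stand out is at the other end of the molecule: 3,4,5-trimethoxyphenyl in place of 4-methoxy-3-nitrophenyl on a carbonyl carbon gives a 3.8-fold higher number from compound 1 to compound 3 (0.58 log units; beyond the scatter). Nothing available explains either step. As far as these compounds go, whether an amine or a fluorine on this aromatic carbon would give a step beyond the scatter stays open. Also open, from the compounds shown here alone, is whether the nitro group alone accounts for the gap between the two aryl ketones.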